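The source may report more compounds than this note shows. Statements on the series, on what has been measured and on what is new or still open speak of the compounds shown alone.

Compound 3 `CC(C)c1cc(NC(=O)n2ccc3cc(Oc4ncnc5c4CNC5)ccc32)no1` stands second highest of the three numbers in a functional assay on the whole organism (strain C57BL/6) for inhibition, with Mus musculus as the target, read by microscopy, with a stated time of 6 days, at a dose of 10 mg/kg by the oral route; a higher number here means more inhibition at the dose given (going by the name of the read-out), a lower number less inhibition: compound 3 gives 96%, and the nearest compound is compound 2 `O=C(Nc1cc(C2CC2)on1)n1ccc2cc(Oc3ncnc4c3CNC4)ccc21`, which gives 98%, a gap of a number 2 percentage points lower from compound 2 to compound 3 (within the scatter). The furthest is compound 1 `CC1(c2cc(NC(=O)n3ccc4cc(Oc5ncnc6c5CNC6)ccc43)n[nH]2)CC1`, which gives 43%, with a number 53 percentage points higher from compound 1 to compound 3 (beyond the scatter) and a number 55 percentage points higher from compound 1 to compound 2 (beyond the scatter).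

Compound 4 `CC1(c2cc(NC(=O)n3ccc4cc(Oc5ncnc6c5CNC6)ccc43)no2)CC1` differs from compound 3 by 1-methylcyclopropyl in place of isopropyl on an aromatic carbon. The step that bears most directly on this change is a number 2 percentage points lower from compound 2 to compound 3 (within the scatter), a swap of one small alkyl for another on the same aromatic carbon that stayed within the scatter. Compound 1 carries 1-methylcyclopropyl, but on a different ring, so its low number cannot be separated from the ring change and says little here. A step of no more than the scatter is therefore expected in this assay, with a number 3 percentage points lower from compound 3 to compound 4 (within the scatter). Compound 4 is estimated at 93%, with a range from 75% to 100%.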

Compound 4, a percentage reported as inhibition, in the whole organism at one dose (the size of the read-out at that dose, not a potency): 90%
The estimate for compound 4 lay 3 percentage points above the measured number; low and high end bracket the measured number.
By their numbers in this assay, from the lowest: compound 1; then compounds 4, 3 and 2 (each within the scatter of the next).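

In this assay the carbon next to the ring oxygen takes 1-methylcyclopropyl as readily as the smaller groups, with a number 6 percentage points lower from compound 3 to compound 4 (within the scatter) and with a number 8 percentage points lower from compound 2 to compound 4 (within the scatter) for methyl in place of hydrogen on a saturated ring carbon, so all three alkyl groups read alike on the 1,2-oxazol-3-yl ring. With 1-methylcyclopropyl held constant, the ring change alone now gives a number 47 percentage points higher from compound 1 to compound 4 (beyond the scatter) and thus ties the low number of compound 1 to the 1H-pyrazol-3-yl ring rather than to the alkyl group. No measurement available here accounts for any of these steps.

The compounds shown leave open how an amine, a carboxylic acid or a longer chain would read on this carbon. They also leave open whether isopropyl or cyclopropyl on the 1H-pyrazol-3-yl ring would give a similar gap.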